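Carrying a Methyl Step Across Two Cores

This account rests on a few compounds, and the source may have more. Where it says the series, first, only, none or still open, it means among the compounds named here.

compound 1 `COC(=O)Nc1cc(-c2ccc(OC[C@@](C)(N)CC(C)C)c(C)c2)ccn1`: 0.08 nM
compound 2 `COC(=O)Nc1cc(-c2ccc(OC[C@@](C)(N)CC(C)C)nc2)ccn1`: 4.9 nM
compound 3 `COC(=O)Nc1cc(-c2ccc(OC[C@@](C)(N)CC(C)C)c(C)c2C)ccn1`: 0.26 nM

Of the compounds shown here, three have been measured in an assay on brain (strain C57BL6) for displacement of a labelled ligand from AP2-associated protein kinase 1 (Mus musculus), read by scintillation counting, with a stated time of 1 h; a higher number here means a weaker inhibitor, a lower number a stronger inhibitor. Compound 1 and compound 3 share one core; compound 2 carries a different core, and the difference between the two cores is not broken down here. Of the three numbers, compound 2 gives the highest, and its gaps to compound 3 and to compound 1 both lie beyond the scatter.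

From compound 1 to compound 3 the change is methyl in place of hydrogen on an aromatic carbon and the step it made is a 3.3-fold higher number from compound 1 to compound 3 (0.51 log units; beyond the scatter).

Compound 4 `COC(=O)Nc1cc(-c2cnc(OC[C@@](C)(N)CC(C)C)cc2C)ccn1` has not yet been measured. It differs from compound 2 by methyl in place of hydrogen on an aromatic carbon. This is the same kind of change as that from compound 1 to compound 3, but not the same: in compound 3 the methyl enters on a six-membered aromatic ring of carbon only, ortho to a methyl group, whereas in compound 4 it enters on a six-membered aromatic ring with one nitrogen, opposite the ring nitrogen, with no neighbouring methyl group.

Among the measured compounds shown here, on the strength of the single measured step of a 3.3-fold higher number from compound 1 to compound 3 (0.51 log units; beyond the scatter), the step from compound 2 to compound 4 in this assay is expected to be a 2.7-fold higher number from compound 2 to compound 4 (0.42 log units; beyond the scatter), modest and in the same direction, with wider uncertainty because only one example of the change exists and its surroundings differ. Compound 4 is therefore estimated at 13 nM, with a range from 3.5 nM to 45 nM.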

Compound 4, inhibition constant: 41 nM
Compound 4: the middle estimate sits 3.2-fold (0.50 log units) below what was measured; measured number inside the range.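

In this assay, methyl in place of hydrogen on an aromatic carbon gave an 8.4-fold higher number from compound 2 to compound 4 (0.92 log units; beyond the scatter), so the change moved the number the same way on the core of compound 2 as it had on the core of compound 1. Set side by side, the two steps point in one direction and cannot be told apart in size: the same change on two cores in this assay, a 3.3-fold higher number (0.51 log units; beyond the scatter) from compound 1 to compound 3 and an 8.4-fold higher number (0.92 log units; beyond the scatter) from compound 2 to compound 4, 2.6-fold (0.41 log units) apart, within the scatter of two such steps. This supports carrying the direction and rough size of the step between these two cores, but it rests on a single pair of steps whose methyl groups enter different surroundings, so it does not show that the step would hold on any other core or what sets its size on either one.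

The compounds shown leave open whether ethyl, methoxy or a chlorine atom in place of the entering methyl would give a step of the same kind. They also leave open whether the methyl step would persist if a shorter chain, such as a 2-aminopropoxy group, replaced the (2-amino-2,4-dimethylpentyl)oxy group.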